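Swapping the sulfonyl aryl group on a chalcone piperazine

The source may report more compounds than this note shows. Statements on the series, on what has been measured and on what is new or still open speak of the compounds shown alone.

Compound 1, `O=C(/C=C/c1ccccc1)c1ccc(N2CCN(c3cccc(Cl)c3Cl)CC2)cc1`: 30.7%
Compound 2, `O=C(/C=C/c1ccccc1)c1ccc(N2CCN(S(=O)(=O)c3ccc4ccccc4c3)CC2)cc1`: 35%

Both compounds were tested in a functional assay on the whole organism (strain Kunming) for inhibition, with Mus musculus as the target, with a stated time of 1 h, at a dose of 40 mg/kg by the oral route; a lower number here means less inhibition, a higher number more inhibition at the dose given (going by the name of the read-out). Compound 2 gives 35% and compound 1 gives 30.7%; the two numbers lie within the scatter of each other, so neither can be set above the other. The unmeasured compound 3, `O=C(/C=C/c1ccccc1)c1ccc(N2CCN(S(=O)(=O)c3ccc(Br)cc3)CC2)cc1`, differs from compound 2 in one place: 4-bromophenyl in place of naphthalen-2-yl on a sulfonyl sulfur. Among the measured compounds shown here, no measured pair shows the effect of such a change, so a step in this assay beyond the scatter is not anticipated in either direction. The expected step is a number 4 percentage points lower from compound 2 to compound 3 (within the scatter). Compound 3 is estimated at 31%, with a range from 16% to 46%.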

Compound 3, a percentage reported as inhibition, in the whole organism at one dose (the size of the read-out at that dose, not a potency): 47.4%
Estimate against measurement, compound 3: 16.4 percentage points below, outside the stated range (above it).
By their numbers in this assay, from the lowest: compounds 1 and 2 (each within the scatter of the next); then compound 3.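

On a sulfonyl sulfur, the choice of aryl group can move the read-out in this assay: 4-bromophenyl in place of naphthalen-2-yl gives a number 12.4 percentage points higher from compound 2 to compound 3 (beyond the scatter) and so goes beyond the scatter, which the earlier pair could not show. On an amine nitrogen in a ring, (4-bromophenyl)sulfonyl in place of 2,3-dichlorophenyl gives a number 16.7 percentage points higher from compound 1 to compound 3 (beyond the scatter) as a second such step. No measurement at hand accounts for either step.

The compounds shown leave open whether the bromine or the single ring goes with the higher number. From the compounds shown here alone, how plain phenyl, 4-chlorophenyl or 4-methoxyphenyl on the sulfonyl sulfur would read also stays open.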